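The source may report more compounds than this note shows. Statements on the series, on what has been measured and on what is new or still open speak of the compounds shown alone.

Values measured so far in a functional assay on C8166 cells (Homo sapiens) for cytotoxicity, read by MTT assay; a higher number here means that more compound is tolerated, a lower number that less compound is tolerated:
- compound 1 `Cc1cccc(C(=O)Nc2cc(Cl)ccc2OCC(=O)Nc2ccc(S(N)(=O)=O)cc2C)c1`: 52900 nM
- compound 2 `Cc1ccc(C(=O)Nc2cc(Cl)ccc2OCC(=O)Nc2ccc(S(N)(=O)=O)cc2C)cc1C`: 84100 nM
- compound 3 `Cc1cc(S(N)(=O)=O)ccc1NC(=O)COc1ccc(Cl)cc1NC(=O)c1ccc(Cl)cc1Cl`: 61100 nM

On these numbers, compound 3 cannot be separated from the other two measured compounds. The steps read a 1.2-fold higher number from compound 1 to compound 3 (0.06 log units; within the scatter) and a 1.4-fold lower number from compound 2 to compound 3 (0.14 log units; within the scatter).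

Next in line is compound 4 `Cc1cc(S(N)(=O)=O)ccc1NC(=O)COc1ccc(Cl)cc1NC(=O)c1ccc(Cl)c(Cl)c1`, which differs from compound 3 as follows: 3,4-dichlorophenyl in place of 2,4-dichlorophenyl on a carbonyl carbon. In words, this is 3,4-dichlorophenyl in place of 2,4-dichlorophenyl on a carbonyl carbon, with the same atoms joined differently.

Going by the values given here, no measured step makes this exact change. The closest evidence comes from the two changes of the group on that same carbonyl carbon, shown above, and from the added methyl, a 1.6-fold higher number from compound 1 to compound 2 (0.20 log units; within the scatter). All three steps lie within the scatter, so among these three compounds, changing this group has produced no measurable shift in this assay. Three compounds are a thin basis, but they give no reason to expect a step beyond the scatter.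

The expected change is small, within the scatter: a 1.1-fold higher number from compound 3 to compound 4 (0.03 log units; within the scatter).

Compound 4 is estimated at 65000 nM, with an expected range of 35000 nM to 115000 nM.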

Compound 4, half-maximal cytotoxic concentration: 158000 nM
Compound 4: the middle estimate sits 2.4-fold (0.39 log units) below what was measured, outside the stated range (above it).
By their numbers in this assay, from the lowest: compounds 1, 3, 2 and 4 (each within the scatter of the next, the first and the last beyond it).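

Among the changes at this place, on a carbonyl carbon whose other neighbour is an amide-type nitrogen, the exchange of 2,4-dichlorophenyl for 3,4-dichlorophenyl gives a step beyond the scatter in this assay (a 2.6-fold higher number from compound 3 to compound 4 (0.41 log units; beyond the scatter)). Going by these compounds alone, the two groups hold the same atoms joined differently, so in this pair the arrangement of the two chlorines alone separates the numbers, which the earlier steps at this place, all within the scatter, did not show. The 3,4-dichlorophenyl group also separates from 3-methylphenyl (a 3.0-fold higher number from compound 1 to compound 4 (0.48 log units; beyond the scatter)), but not from 3,4-dimethylphenyl (a 1.9-fold higher number from compound 2 to compound 4 (0.27 log units; within the scatter)), so in this assay the 3,4-dichlorophenyl and 3,4-dimethylphenyl groups cannot be told apart.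

Nothing available here bears on why the two dichlorophenyl isomers differ.

Going by these compounds, it remains open whether the same gap between isomers appears when bromine or fluorine stands in place of chlorine on this ring. On these data alone, it is also open how the number responds to a carboxylic acid, an amine or a methoxy group on the ring at this carbonyl carbon.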